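Chloro to isopropyl on compound 2

A few compounds are considered here, and "the series" means these few. Any claim that something is new, unique, unknown or untested is made for them only; others in the source may bear on it.

Compound 2 (`CCCC(=O)NC(c1ccc(Cl)cc1)c1cc(Cl)c2cccnc2c1O`) gives 100 nM in a functional assay on Daoy cells (Homo sapiens) for antiproliferative activity, read by trypan blue exclusion and crystal violet staining, with a stated time of 72 h (a higher number here means a weaker inhibitor, a lower number a stronger inhibitor), and stands within the scatter of compound 3 (`CCCCC(=O)NC(c1cc(Cl)cc(Cl)c1)c1ccc2cccnc2c1O`) at 140 nM in the same read-out. Compound 1 (`O=C(NCc1ccc2cccnc2c1O)C1CCCCC1`) gives 720 nM and lies beyond the scatter from compound 2 on the weaker side.

Compound 4 (`CCCC(=O)NC(c1ccc(C(C)C)cc1)c1cc(Cl)c2cccnc2c1O`) has isopropyl in place of chloro on an aromatic carbon, para to a large group (isopropyl in place of chloro on an aromatic carbon), so 4-chlorophenyl becomes 4-isopropylphenyl. Among the measured compounds shown here, no measured pair isolates this change or any other single change, so the series offers no direct precedent for its size.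

In this assay a small step toward a higher number is expected, probably not beyond the scatter, and the estimated change is a 1.7-fold higher number from compound 2 to compound 4 (0.23 log units; within the scatter) on this basis alone. For the measured compounds named here, the range is kept wide because only three measured compounds support it.

Compound 4 is estimated at 170 nM with an expected range of 60 nM to 500 nM in this series.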

Compound 4, half-maximal inhibitory concentration: 90 nM
The estimate for compound 4 lay 1.9-fold (0.28 log units) above the measured number, within the range that was stated.
By their numbers in this assay, from the lowest: compounds 4, 2 and 3 (each within the scatter of the next); then compound 1.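

Read in this assay the change from chloro to isopropyl gives a 1.1-fold lower number from compound 2 to compound 4 (0.05 log units; within the scatter) and is the first single-place step available in the series. On this aromatic carbon, para to a large group, 4-isopropylphenyl and 4-chlorophenyl are not separated, even though three carbon heavy atoms replace one chlorine. No measurement available here accounts for this result.

The compounds shown cover only chloro and isopropyl at this position, so it remains open whether the same holds for a group carrying hydrogen-bond donors or acceptors, such as an amine or a carboxylic acid. A tert-butyl group or a longer alkyl chain on the same carbon would show whether the lack of separation extends to groups larger than isopropyl.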